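This account rests on a few compounds, and the source may have more. Where it says the series, first, only, none or still open, it means among the compounds named here.

Compound 2 `C/C=C/C(=O)Nc1cc2c(N3CCCc4ccccc43)ncnc2cc1OC` is the weakest-looking of three related compounds in a functional assay on MCF7 cells (Homo sapiens) for antiproliferative activity, read by MTT assay, with a stated time of 72 h (a higher number here means a weaker inhibitor, a lower number a stronger inhibitor), where compound 2 gives 12700 nM. Compound 1 `COc1cc2ncnc(N3CCc4ccccc43)c2cc1NC(=O)/C=C/C(C)C` gives 6780 nM in this assay, a gap that sits within the scatter, while compound 3 `C/C=C/C(=O)Nc1cc2c(N3CCCc4ccccc43)ncnc2cc1O[C@@H]1CCOC1` gives 5930 nM, and the change a 2.1-fold lower number from compound 2 to compound 3 (0.33 log units; beyond the scatter) shows a modest gain. Compound 4 `COc1cc2ncnc(N3CCCc4ccccc43)c2cc1NC(=O)/C=C/CN1CCCC1` departs from compound 2 by a different route: pyrrolidin-1-yl in place of hydrogen on a saturated chain carbon bound to a double-bonded chain carbon. For the measured compounds named here, none of the measured steps alters this chain, so no step here bears directly on it, and the expectation rests on the shared core alone. A shift of about a 1.8-fold lower number from compound 2 to compound 4 (0.26 log units; within the scatter) is expected, with a wide range. Compound 4 is therefore estimated at 7000 nM in this assay, between 2000 nM and 25000 nM.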

Compound 4, half-maximal inhibitory concentration: 3190 nM
Estimate against measurement, compound 4: 2.2-fold (0.34 log units) above; measured number inside the range.
By their numbers in this assay, from the lowest: compounds 4, 3, 1 and 2 (each within the scatter of the next, the first and the last beyond it).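

The earlier step changed only the group on an oxygen; this one shows that a change on the other side chain also moves the number in this assay. Pyrrolidin-1-yl in place of hydrogen on the saturated chain carbon gives a 4.0-fold lower number from compound 2 to compound 4 (0.60 log units; beyond the scatter), so this carbon can carry a five-membered ring containing nitrogen without loss. Nothing available explains this gain.

On these data alone, whether the gain comes from the nitrogen or from the ring stays open: dimethylamino, morpholin-4-yl or cyclopentyl on the same carbon would help separate these. Also open, as far as these compounds go, is whether it would add to the gain from oxolan-3-yl on the oxygen.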